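This account rests on a few compounds, and the source may have more. Where it says the series, first, only, none or still open, it means among the compounds named here.

Compound 1 `COc1cc(-c2ccnc3cc(-c4ccc5cc[nH]c5c4)nn23)cc(OC)c1OC`: 170 nM
Compound 2 `COc1cc(-c2ccnc3cc(-c4c[nH]c5ccccc45)nn23)cc(OC)c1OC`: 29 nM
Compound 3 `COc1cc(-c2ccnc3cc(-c4ccccc4)nn23)cc(OC)c1OC`: 208 nM

In a functional assay on A549 cells (Homo sapiens) for inhibition, read by CCK-8 assay, with a stated time of 48 h (a lower number here means a stronger inhibitor, a higher number a weaker inhibitor), compound 3 gives 208 nM, the highest number of the three. Its nearest neighbour is compound 1, and a 1.2-fold higher number from compound 1 to compound 3 (0.09 log units; within the scatter), so the two cannot be told apart. Compound 2 sits furthest away: a 7.2-fold higher number from compound 2 to compound 3 (0.86 log units; beyond the scatter), while a 5.9-fold lower number from compound 1 to compound 2 (0.77 log units; beyond the scatter).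

Compound 4 `COc1cc(-c2ccnc3cc(-c4ccc(C)c(C)c4)nn23)cc(OC)c1OC` carries 3,4-dimethylphenyl in place of phenyl on an aromatic carbon. Going by the values given here, no measured step adds carbon substituents to the phenyl itself; the steps that bear on the change are those at the same position. There, phenyl against 1H-indol-6-yl made no difference beyond the scatter, whereas phenyl against 1H-indol-3-yl was a modest step. Enlarging the group at this position can therefore matter, but need not. Among the compounds with values here, with no direct precedent for 3,4-dimethylphenyl, compound 4 is expected to stay close to compound 3, with at most a small move to a lower number: a 1.4-fold lower number from compound 3 to compound 4 (0.14 log units; within the scatter). The estimate for compound 4 in this assay is 150 nM, with a range from 55 nM to 450 nM.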

Compound 4, half-maximal inhibitory concentration: 272 nM
Compound 4: middle estimate off by 1.8-fold (0.26 log units), on the low side, and the stated range covers the measured number.
By their numbers in this assay, from the lowest: compound 2; then compounds 1, 3 and 4 (each within the scatter of the next).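

In this assay, placing 3,4-dimethylphenyl instead of phenyl on this aromatic carbon of the five-membered ring, two ring bonds from the ring nitrogen, gives a step that stays within the scatter (a 1.3-fold higher number from compound 3 to compound 4 (0.12 log units; within the scatter)), so the carbon added to the phenyl does not separate the two compounds. The comparison with the 1H-indol-6-yl group also stays within the scatter (a 1.6-fold higher number from compound 1 to compound 4 (0.20 log units; within the scatter)), whereas the comparison with the 1H-indol-3-yl group lies beyond it (a 9.4-fold higher number from compound 2 to compound 4 (0.97 log units; beyond the scatter)), leaving compound 2 apart from compounds 1, 3 and 4 among the four groups now compared at this position. Nothing available accounts for this separation, and the numbers alone cannot explain it.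

The compounds shown leave open whether a phenyl ring bearing a hydroxyl, an amine or a carboxylic acid in place of the two methyl groups would stay with compounds 3 and 4 or move toward compound 2. They also leave open whether the lower number of compound 2 would persist with a methyl group on the indole nitrogen.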